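Growing the Chain on an Aromatic Nitrogen: Methyl to Cyclohexyl

This account rests on a few compounds, and the source may have more. Where it says the series, first, only, none or still open, it means among the compounds named here.

Of the compounds shown here, three sharing one core have been measured in an assay on Huh-7 cells for agonist activity at Bile acid receptor (Homo sapiens), read by a luciferase reporter; on this read-out higher numbers stand for an effect only at larger amounts of compound and lower numbers for an effect already at smaller amounts. Compound 1 `CC(C)c1onc(-c2c(Cl)cccc2Cl)c1COc1ccc(-c2nc3ccc(C(=O)O)cc3n2Cc2ccc(F)cc2)cc1` gives 3.31 nM. Compound 2 `CCn1c(-c2ccc(OCc3c(-c4c(Cl)cccc4Cl)noc3C(C)C)cc2)nc2ccc(C(=O)O)cc21` gives 2.31 nM, the lowest of the three numbers. Compound 3 `CC(C)Cn1c(-c2ccc(OCc3c(-c4c(Cl)cccc4Cl)noc3C(C)C)cc2)nc2ccc(C(=O)O)cc21` gives 5.26 nM. The steps of a 1.4-fold lower number from compound 1 to compound 2 (0.16 log units; within the scatter) and a 1.6-fold higher number from compound 1 to compound 3 (0.20 log units; within the scatter) both stay within the scatter, while the step of a 2.3-fold higher number from compound 2 to compound 3 (0.36 log units; beyond the scatter) lies just beyond it, a modest rise.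

Compound 4 `CC(C)c1onc(-c2c(Cl)cccc2Cl)c1COc1ccc(-c2nc3ccc(C(=O)O)cc3n2CC2CCCCC2)cc1` has not yet been measured in this assay. It differs from compound 2 by cyclohexyl in place of methyl on a saturated chain carbon bound to an aromatic nitrogen. Among the compounds with values here, the only measured step that bears directly on this change is a 2.3-fold higher number from compound 2 to compound 3 (0.36 log units; beyond the scatter), where a larger group on the same carbon went with a modestly higher number. Cyclohexyl is larger again than isopropyl, and no measured compound shows what happens beyond isopropyl, so the range must stay wide. Given a 2.3-fold higher number from compound 2 to compound 3 (0.36 log units; beyond the scatter), a similar or somewhat larger rise in the number is expected for compound 4, though a result within the scatter of compound 2 cannot be ruled out.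

On these grounds compound 4 is estimated at 6 nM in this assay, with a range from 2.5 nM to 15 nM. This estimate corresponds to an expected step of a 2.6-fold higher number from compound 2 to compound 4 (0.41 log units; beyond the scatter).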

Compound 4, half-maximal effective concentration: 0.52 nM
Compound 4: the middle estimate sits 12-fold (1.06 log units) above what was measured; the whole stated range lies above it.
By their numbers in this assay, from the lowest: compound 4; then compounds 2, 1 and 3 (each within the scatter of the next, the first and the last beyond it).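

In this assay, cyclohexyl on a saturated chain carbon bound to an aromatic nitrogen gives the lowest number of the four compounds, with a 4.4-fold lower number from compound 2 to compound 4 (0.65 log units; beyond the scatter) and a 10-fold lower number from compound 3 to compound 4 (1.00 log units; beyond the scatter). The earlier compounds shown here hinted that a larger group here might raise the number, but this result shows that size alone does not set the order: isopropyl in compound 3 goes against any simple trend, since the number rises from methyl to isopropyl and then falls with the still larger cyclohexyl. The change from 4-fluorophenyl to cyclohexyl also gives a 6.4-fold lower number from compound 1 to compound 4 (0.80 log units; beyond the scatter), so two six-membered rings at this place are not interchangeable, although this step changes both the ring type and the presence of fluorine.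

Nothing available explains why cyclohexyl gives the lowest number at this position. Plain phenyl would separate the effect of the ring from that of fluorine, while cyclopentyl, a longer chain such as n-butyl, or a cyclohexyl ring carrying an amine would show how narrow this low-number result is.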